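Swapping an amide linker for a pyridine ring

The source may hold more compounds than are shown below. What is called first, only, known or untested is meant among the compounds shown, and "the series" means these compounds.

Of the compounds shown here, two with a shared core have been tested in an assay on C3H 10T1/2 cells for inhibition of Sonic hedgehog protein (Mus musculus), read by a luciferase reporter; on this read-out higher numbers stand for weaker inhibition and lower numbers for stronger inhibition. Compound 1, `Cc1nc(C(F)(F)F)ccc1C(=O)Nc1ccc(Cl)c(-n2cc3ccccc3n2)c1`, gives 80 nM. Compound 2, `Cc1nc(C(F)(F)F)ccc1C(=O)Nc1ccc(Cl)c(C(=O)Nc2ccccc2)c1`, gives 140 nM. Within the data shown here, of these two numbers compound 2 holds the higher one, but the only step that connects them, a 1.8-fold higher number from compound 1 to compound 2 (0.24 log units; within the scatter), is within the scatter, so the two compounds cannot be told apart on this read-out.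

Compound 3, `Cc1nc(C(F)(F)F)ccc1C(=O)Nc1ccc(Cl)c(-c2cccnc2)c1`, has not been measured. It differs from compound 2 in one place: pyridin-3-yl in place of phenylcarbamoyl on an aromatic carbon. Among the measured compounds shown here, the one measured step that bears on this position, a 1.8-fold higher number from compound 1 to compound 2 (0.24 log units; within the scatter), shows that exchanging the group there made no difference beyond the scatter. For the measured compounds named here, nothing among the measured compounds shows a pyridin-3-yl at this place, so the expectation rests on that single step alone and carries a wide range.

On this basis compound 3 is expected to give about 90 nM in this assay, with a range from 30 nM to 270 nM. The estimated step of a 1.6-fold lower number from compound 2 to compound 3 (0.19 log units; within the scatter) is therefore expected to stay within the scatter.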

Compound 3, half-maximal inhibitory concentration: 10000 nM
Beside the measured number, compound 3's estimate is 110-fold (2.05 log units) below it, outside the stated range (above it).
By their numbers in this assay, from the lowest: compounds 1 and 2 (each within the scatter of the next); then compound 3.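

In this assay this position looked forgiving at first, since a 2H-indazol-2-yl in compound 1 and a phenylcarbamoyl in compound 2 could not be told apart, but pyridin-3-yl shows that it is far from indifferent to what it carries. Measured against the phenylcarbamoyl, the change gives a 71-fold higher number from compound 2 to compound 3 (1.85 log units; beyond the scatter) and measured against the 2H-indazol-2-yl it gives a 130-fold higher number from compound 1 to compound 3 (2.10 log units; beyond the scatter) so both groups that hold inhibition differ sharply from this one, and the loss of phenylcarbamoyl alone does not go with the drop, as compound 1 lacks that group too and stays strong. Nothing measured for these compounds explains why the pyridin-3-yl falls so far.

The compounds shown do not separate the ring nitrogen of pyridin-3-yl from the smaller size of the entering group, which has fewer heavy atoms than the phenylcarbamoyl it replaces. A plain phenyl, a pyridin-4-yl or a pyridin-3-yl carrying a methyl group at this place would help tell whether the position of that nitrogen, its presence or the size of the group goes with the loss.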